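Adding a Methoxy Group in a Cytotoxicity Series

The compounds below may be only part of what the source reports. "The series", "measured", "known", "first", "only" and "open" are said of these compounds alone.

Compound 1 `COc1cccc(/C=C2\CCC/C(=C\c3ccc(O)cc3)C2=O)c1OC` and compound 2 `COc1cc(/C=C2\CCC/C(=C\c3cccc(OC)c3OC)C2=O)ccc1O` share a core, and compound 2 differs from compound 1 by methoxy in place of hydrogen on an aromatic carbon. In an ADME assay on NHDF cells (Homo sapiens) for cytotoxicity, read by MTT assay, with a stated time of 72 h (on this read-out lower numbers stand for stronger inhibition and higher numbers for weaker inhibition), compound 1 gives only a limit, > 50000 nM. Compound 2 gives 14300 nM, so the change made an at least 3.4-fold lower number from compound 1 to compound 2 (0.54 log units; beyond the scatter), a step whose size rests on (the limit of > 50000 nM in this assay, at which 1 of the 3 values shown sits). Compound 3 `COc1cc(/C=C2\CCC/C(=C\c3ccc(OC)c(OC)c3)C2=O)cc(OC)c1` gives 6500 nM in this assay; the difference between its core and that of compound 1 is not broken down here. Compound 4 `COc1ccc(/C=C2\CCC/C(=C\c3cc(OC)c(OC)c(OC)c3)C2=O)cc1OC` differs from compound 3 by methoxy in place of hydrogen on an aromatic carbon, the same kind of change, though here the entering group sits ortho to two methoxy groups and para to a large group rather than ortho to a hydroxy group and meta to a large group. Beside the earlier step, compound 4 is expected to show a 1.6-fold lower number from compound 3 to compound 4 (0.21 log units; within the scatter), which rests on the step seen from compound 1 to compound 2, an at least 3.4-fold lower number from compound 1 to compound 2 (0.54 log units; beyond the scatter). Compound 4 is therefore estimated at 4000 nM in this assay, between 1500 nM and 15000 nM.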

Compound 4, half-maximal inhibitory concentration: 5800 nM
Compound 4: middle estimate off by 1.5-fold (0.16 log units), on the low side; measured number inside the range.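

In this assay, methoxy in place of hydrogen on an aromatic carbon gave a 1.1-fold lower number from compound 3 to compound 4 (0.05 log units; within the scatter), so on this core the change makes no difference that can be told from scatter. The change therefore did not carry over at the same size from one core to the other: the same change on two cores in this assay, an at least 3.4-fold lower number (0.54 log units; beyond the scatter) from compound 1 to compound 2 and a 1.1-fold lower number (0.05 log units; within the scatter) from compound 3 to compound 4, at least 3.1-fold (0.49 log units) apart, beyond the scatter of two such steps. Compound 1 gives only a limit, so the earlier step has no fixed size, and two cores set no rule for the series: the limit of > 50000 nM in this assay, at which 1 of the 4 values shown sits.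

The compounds shown leave open whether the gap between the steps follows from where the entering methoxy sits or from the rest of each core. They also leave open how an amine, a carboxylic acid or a longer chain in that place would read in this assay.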